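A Flat Series Meets a Larger Substituent

A few compounds are considered here, and "the series" means these few. Any claim that something is new, unique, unknown or untested is made for them only; others in the source may bear on it.

Three compounds sharing one core read alike in a functional assay on A549 cells (Homo sapiens) for inhibition, read by MTT assay, with a stated time of 72 h; on this read-out higher numbers stand for weaker inhibition and lower numbers for stronger inhibition. Compound 1 `O=C1C=CC(O)(c2cc3ccccc3n2S(=O)(=O)c2ccccc2)C=C1` gives 500 nM, compound 2 `O=C1C=CC(O)(c2cc3ccc(F)cc3n2S(=O)(=O)c2ccccc2)C=C1` gives 500 nM, and compound 3 `Cc1ccc(S(=O)(=O)n2c(C3(O)C=CC(=O)C=C3)cc3ccccc32)cc1` gives 500 nM, which places compound 3 level with the other two.

The unmeasured compound 4 `CCOC(=O)Nc1ccc(S(=O)(=O)n2c(C3(O)C=CC(=O)C=C3)cc3ccccc32)cc1` differs from compound 3 in one place: (ethoxycarbonyl)amino in place of methyl on an aromatic carbon. In words, (ethoxycarbonyl)amino stands in place of methyl on an aromatic carbon, para to a large group.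

Among the measured compounds shown here, two measured steps bear on this change. Fluoro in place of hydrogen on an aromatic carbon gave no change at the digits printed from compound 1 to compound 2 (within the scatter), and methyl in place of hydrogen on an aromatic carbon gave no change at the digits printed from compound 1 to compound 3 (within the scatter). The methyl introduced in the second step is the very group that now leaves. Both steps involve only small groups, so they offer no direction for a group as large as (ethoxycarbonyl)amino, and the range has to stay wide. The expected outcome is no change at the digits printed from compound 3 to compound 4 (within the scatter), with neither direction favoured. In this assay the estimate for compound 4 is 500 nM, with an expected range of 180 nM to 1500 nM.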

Compound 4, half-maximal inhibitory concentration: 500 nM
Beside the measured number, compound 4's estimate shows no gap at the digits printed; low and high end bracket the measured number.
By their numbers in this assay, from the lowest: compounds 1, 2, 3 and 4 (each within the scatter of the next).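

In this assay the exchange of methyl for (ethoxycarbonyl)amino gave no change at the digits printed from compound 3 to compound 4 (within the scatter) and the same group in place of hydrogen gave no change at the digits printed from compound 1 to compound 4 (within the scatter) so the level reading now reaches well beyond the small groups seen before. Until this result, the only change shown on this aromatic carbon, para to a large group, was a methyl, which left open whether a much larger group carrying a hydrogen-bond donor and hydrogen-bond acceptors would be accepted, and here such a group leaves the read-out level with the earlier compounds. The data offer nothing that explains why the reading stays the same across these changes.

What the compounds shown leave open is whether this level reading is a general feature of the place or holds only for the groups seen so far, since a free amine, a carboxylic acid or a longer chain could still move the number in either direction. They also leave open whether a group with a ring at this place, such as a phenyl, would read the same.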